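This account rests on a few compounds, and the source may have more. Where it says the series, first, only, none or still open, it means among the compounds named here.

Measured so far:
compound 1, `CN(Cc1cc(=O)oc2cc(O)ccc12)c1ccccc1` — 6000 nM
compound 2, `O=c1cc(CSc2cccs2)c2ccc(O)cc2o1` — 420 nM

The study set out here rests on two measured compounds and one that remains to be tested. In an assay on HeLa cells for inhibition of 17-beta-hydroxysteroid dehydrogenase type 3 (Homo sapiens) (on this read-out lower numbers stand for stronger inhibition and higher numbers for weaker inhibition), compound 1 gives 6000 nM, whereas compound 2 gives 420 nM, which is the lower of the two numbers and lies beyond the usual scatter from the number of compound 1. Compound 2 therefore stands as the stronger inhibitor of the pair on this assay.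

Compound 3, `Cn1ccnc1SCc1cc(=O)oc2cc(O)ccc12`, is the compound still to be measured. It differs from compound 2 in one place: 1-methyl-1H-imidazol-2-yl in place of thiophen-2-yl on a sulfur. Among the measured compounds shown here, no pair of measured compounds differs in a comparable single place, so there is no measured step to lean on for this kind of exchange; the expectation has to be drawn from the structures alone.

Compound 3 is estimated to give 1000 nM, with a range from 300 nM to 4000 nM. That estimate means a step from compound 2 to compound 3 of a 2.4-fold higher number from compound 2 to compound 3 (0.38 log units; beyond the scatter), a modest weakening that may well remain within the scatter, and is expected rather than known.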

Compound 3, half-maximal inhibitory concentration: 91 nM
For compound 3 the middle estimate is 11-fold (1.04 log units) above the measured one; the measured number lies below the stated range.
By their numbers in this assay, from the lowest: compound 3; then compound 2; then compound 1.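

On this assay, putting 1-methyl-1H-imidazol-2-yl in place of thiophen-2-yl on the sulfur gives a 4.6-fold lower number from compound 2 to compound 3 (0.66 log units; beyond the scatter), so this place in the series responds measurably to the choice of five-membered aromatic ring. The change also shows that inhibition on this read-out does not depend on keeping thiophen-2-yl there, since the entering ring, with 2 hetero atoms and 2 hydrogen-bond acceptors against 1 hetero atom and 1 hydrogen-bond acceptor in the ring that leaves, comes with the lower number. The exchange alters the ring's hetero atoms and adds a methyl group in a single step, and nothing available explains the gain or assigns it to either feature.

The compounds shown leave open whether the ring nitrogens or the methyl group carry the step, which a plain imidazol-2-yl on the same sulfur would help to separate. They also leave open how a six-membered ring such as pyridin-2-yl or phenyl would stand on that sulfur, and whether a longer chain between the sulfur and the shared core would keep the lower number.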